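Benzyl variations on the shared hydroxypiperidine core

The compounds below may be only part of what the source reports. "The series", "measured", "known", "first", "only" and "open" are said of these compounds alone.

Measured so far:
- compound 1, `O=c1c2cnn(-c3ccc(F)cc3)c2ncn1CC1(O)CCN(Cc2ccc(Br)cc2)CC1`: 6700 nM
- compound 2, `N#Cc1ccccc1CN1CCC(O)(Cn2cnc3c(cnn3-c3ccc(F)cc3)c2=O)CC1`: 8100 nM
- compound 3, `Cc1ccc(CN2CCC(O)(Cn3cnc4c(cnn4-c4ccc(F)cc4)c3=O)CC2)cc1`: "not determined" (no result reported)

In an assay on Sf21 cells for inhibition of ubiquitin carboxyl-terminal hydrolase 7 (Homo sapiens), read by spectrophotometry, with stated times of 30 min and 2 h (a higher number here means a weaker inhibitor, a lower number a stronger inhibitor), compound 1 gives 6700 nM and compound 2 gives 8100 nM. Going by the values given here, the only step that can be read across the set, a 1.2-fold higher number from compound 1 to compound 2 (0.08 log units; within the scatter), falls within the scatter, so compound 1 and compound 2 cannot be told apart on these numbers; compound 3 gives "not determined" (no result reported) and so contributes no figure. Compound 1 is therefore the anchor for what follows only in the sense that it is the parent of the next change.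

Compound 4, `COC(=O)c1ccc(CN2CCC(O)(Cn3cnc4c(cnn4-c4ccc(F)cc4)c3=O)CC2)c(F)c1`, differs from compound 1 in one place: 2-fluoro-4-(methoxycarbonyl)phenyl in place of 4-bromophenyl on a saturated chain carbon bound to an amine nitrogen in a ring

Among the compounds with values here, the single measured step that bears on this, a 1.2-fold higher number from compound 1 to compound 2 (0.08 log units; within the scatter), exchanged one group on the same saturated chain carbon for another and moved the number by less than the scatter. The change to compound 4 is larger in what is counted, with two hydrogen-bond acceptors entering, but nothing measured here connects such a change to a shift in this assay. Within the data shown here, the expectation for compound 4 is thus a step of about a 1.0-fold higher number from compound 1 to compound 4 (0.02 log units; within the scatter), no clearer direction than that, with a broad range because the set gives only one relevant step. Compound 4 is estimated at 7000 nM, between 2500 nM and 20000 nM.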

Compound 4, half-maximal inhibitory concentration: 800 nM
Compound 4: the middle estimate sits 8.8-fold (0.94 log units) above what was measured; the whole stated range lies above it.
By their numbers in this assay, from the lowest: compound 4; then compounds 1 and 2 (each within the scatter of the next).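

In this assay the group on the saturated chain carbon bound to an amine nitrogen in a ring proves able to move the number, with an 8.4-fold lower number from compound 1 to compound 4 (0.92 log units; beyond the scatter) and a 10-fold lower number from compound 2 to compound 4 (1.01 log units; beyond the scatter), whereas the earlier exchange gave only a 1.2-fold higher number from compound 1 to compound 2 (0.08 log units; within the scatter) and left compound 1 and compound 2 indistinguishable. Compound 4 therefore holds the lowest number among the compounds with a reported value, and its entering 2-fluoro-4-(methoxycarbonyl)phenyl differs from both groups it replaces by carrying a fluorine and a methoxycarbonyl at once, so the step belongs to the whole group and cannot be divided between those two parts. Nothing available explains why this group gives the lower number.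

On these data alone, it remains open whether the step rests on the fluorine, on the methoxycarbonyl or only on the two together. As far as these compounds go, it is equally open how a carboxylic acid or a primary amide in place of the methoxycarbonyl would read in this assay, which would show whether the ester itself matters at this position.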